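Tetrazolyl carbamoyl chain tail replacing a triazole terminus

The source may hold more compounds than are shown below. What is called first, only, known or untested is meant among the compounds shown, and "the series" means these compounds.

The shared core is a hydroxyacetophenone bearing an ethyl group and an alkoxy chain. Compound 1 `CCc1cc(C(C)=O)c(O)cc1OCCCCCCSC` carries a (methylsulfanyl)methyl terminus; in an assay on isolated protein for inhibition of leukotriene B4 receptor 1 (Homo sapiens), tested at 10 uM (a higher number here means more inhibition at the concentration tested (going by the name of the read-out), a lower number less inhibition), compound 1 gives 71%. Compound 2 `CCc1cc(C(C)=O)c(O)cc1OCCCCCn1cncn1` carries a 1H-1,2,4-triazol-1-yl terminus instead, and in this assay compound 2 gives 82%, the higher of the two numbers; the change gave a number 11 percentage points higher from compound 1 to compound 2 (beyond the scatter). Compound 3 `CCc1cc(C(C)=O)c(O)cc1OCCCCCCC(=O)Nc1nn[nH]n1` is not yet measured. It differs from compound 2 as follows: ((2H-tetrazol-5-yl)carbamoyl)methyl in place of 1H-1,2,4-triazol-1-yl on a saturated chain carbon, five bonds along the chain from an oxygen on an aromatic ring. Within the data shown here, only one measured step touches the same chain position, that from compound 1 to compound 2, and it was modest; no measured pair shows a tetrazole or an amide at this position, so the direction is open. For compound 3 a step of a number 4 percentage points lower from compound 2 to compound 3 (within the scatter) is expected, within the scatter. Compound 3 is therefore estimated at 78%, with a range from 55% to 95%.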

Compound 3, a percentage reported as inhibition, at one concentration (the size of the read-out at that concentration, not a potency): 101%
Beside the measured number, compound 3's estimate is 23 percentage points below it; the whole stated range lies below it.
By their numbers in this assay, from the lowest: compound 1; then compound 2; then compound 3.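

Swapping the 1H-1,2,4-triazol-1-yl terminus for ((2H-tetrazol-5-yl)carbamoyl)methyl on the saturated chain carbon gave a number 19 percentage points higher from compound 2 to compound 3 (beyond the scatter) in this assay, so this position accepts a larger terminus that holds both a carbonyl and a tetrazole ring without any loss of inhibition. Measured against the methylsulfanyl end, the same tail gave a number 30 percentage points higher from compound 1 to compound 3 (beyond the scatter), the widest gap among the three compounds. Nothing available explains why this terminus reads higher.

The compounds shown do not separate the contribution of the amide from that of the tetrazole ring, which a carboxylic acid or a plain primary amide at the chain end would help to settle. They also leave open how a shorter or longer chain would carry the same tail, and, since each reading comes from a single concentration, how potency would rank.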